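A few compounds are considered here, and "the series" means these few. Any claim that something is new, unique, unknown or untested is made for them only; others in the source may bear on it.

Measured in a functional assay on SMMC-7721 cells (Homo sapiens) for cytotoxicity, read by MTT assay, with a stated time of 24 h; on this read-out lower numbers stand for stronger inhibition and higher numbers for weaker inhibition:
- compound 1 `O=C1/C(=C/c2cccnc2)CNC/C1=C\c1ccccc1F`: > 20000 nM (a limit of the assay)
- compound 2 `O=C1/C(=C/c2ccncc2)CN(S(=O)(=O)c2ccc(F)cc2)C/C1=C\c1ccccc1F`: > 20000 nM (a limit of the assay)
- compound 3 `O=C1/C(=C/c2cccnc2)CNC/C1=C\c1ccccc1C(F)(F)F`: 5100 nM

Within the data shown here, compound 3 holds the only actual number in this assay, and the other two entries sit at the limit of > 20000 nM in this assay, at which 2 of the 3 values shown sit.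

The next compound is compound 4 `O=C1/C(=C/c2cccnc2)CN(S(=O)(=O)c2ccc(Cl)cc2)C/C1=C\c1ccccc1C(F)(F)F`, which differs from compound 3 by (4-chlorophenyl)sulfonyl in place of hydrogen on an amine nitrogen in a ring. In words, (4-chlorophenyl)sulfonyl takes the place of hydrogen on an amine nitrogen in a ring.

Among the measured compounds shown here, the one measured step, an at least 3.9-fold lower number from compound 1 to compound 3 (0.59 log units; beyond the scatter), is trifluoromethyl in place of fluoro on an aromatic carbon. Compound 4 keeps the trifluoromethyl, so this step supports starting from compound 3 at 5100 nM, but it says nothing about the amine nitrogen. For the measured compounds named here, no measured step covers a change at that nitrogen. Compound 2 also carries a sulfonyl group on that nitrogen, but it differs from compound 4 in other places as well. For compound 2 the entry of > 20000 nM is a limit.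

Going by the values given here, with no direct precedent, no step beyond the scatter is expected in this assay, and the direction remains open. The expected change is a 1.2-fold higher number from compound 3 to compound 4 (0.07 log units; within the scatter). For compound 4 the estimated value is 6000 nM, with an expected range of 1800 nM to 20000 nM.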

Compound 4, half-maximal inhibitory concentration: 4880 nM
The estimate for compound 4 lay 1.2-fold (0.09 log units) above the measured number; the range from low to high includes it.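

In this assay, among these compounds, (4-chlorophenyl)sulfonyl in place of hydrogen on the amine nitrogen in a ring gives a 1.0-fold lower number from compound 3 to compound 4 (0.02 log units; within the scatter), the only measured step at this nitrogen, so with trifluoromethyl on the aromatic carbon the hydrogen there is not required to hold the read-out. Among the compounds shown here, the entering group brings 10 heavy atoms and one six-membered aromatic ring of carbon only, and both compounds of this step still give actual numbers rather than the limit: the limit of > 20000 nM in this assay, at which 2 of the 4 values shown sit. Compound 2, which also carries a sulfonyl group on that nitrogen, gives > 20000 nM, a limit, and it differs from compound 4 in more than one place, so it adds no step here.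

Open, as far as these compounds go, is whether this nitrogen accepts other groups in the same way, such as an acetyl amide, a methyl or a longer alkyl chain, and whether the chlorine on the entering group matters, for instance against a methoxy or a carboxylic acid in its place. Also open, from the compounds shown here alone, is how the same sulfonyl change reads with fluoro in place of trifluoromethyl on the shared core.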